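Methoxy replaces the sulfanyl group of compound 3

The compounds below may be only part of what the source reports. "The series", "measured", "known", "first", "only" and "open" are said of these compounds alone.

In a functional assay on the whole organism with Mus musculus as the target (on this read-out lower numbers stand for an effect already at smaller amounts and higher numbers for an effect only at larger amounts of compound), compound 1 `Cc1c(C)c2c(c(C)c1N)CC(C)(CSc1ccc(F)cc1)O2` gives 17.9 mg/kg and compound 3 `Cc1c(C)c2c(c(C)c1N)CC(C)(CSc1nccn1C)O2` gives 37.1 mg/kg as the higher of the two exact numbers. Compound 2 `Cc1c(C)c2c(c(C)c1N)CC(C)(CSc1ccc(O)cc1)O2` gives > 50 mg/kg as a limit of the assay, not a number.

Compound 4 `COCC1(C)Cc2c(C)c(N)c(C)c(C)c2O1` carries methoxy in place of (1-methyl-1H-imidazol-2-yl)sulfanyl on a saturated chain carbon bound to a saturated ring carbon and so has no sulfur. The measured steps that bear on this all change the group on the sulfur and keep the sulfur: a 2.1-fold higher number from compound 1 to compound 3 (0.32 log units; beyond the scatter) is modest, an at least 2.7-fold higher number from compound 1 to compound 2 (0.44 log units; beyond the scatter) is at least modest, and an at least 1.3-fold lower number from compound 2 to compound 3 (0.12 log units; that floor lies within the scatter) has a floor within the scatter. None of them removes the sulfur, so they are only a loose guide and favour no direction. In this assay no step beyond the scatter is therefore expected. The step expected is a 1.1-fold higher number from compound 3 to compound 4 (0.03 log units; within the scatter) by estimate, which stays within the scatter. For compound 4 the estimate is 40 mg/kg (expected range 15 mg/kg to 90 mg/kg).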

Compound 4, dose for 50% inhibition: 20.1 mg/kg
For compound 4 the middle estimate is 2.0-fold (0.30 log units) above the measured one, and the stated range covers the measured number.
By their numbers in this assay, from the lowest: compounds 1, 4 and 3 (each within the scatter of the next, the first and the last beyond it). At a limit, above all of these: compound 2.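

In this assay, the move from (1-methyl-1H-imidazol-2-yl)sulfanyl to methoxy gives a 1.8-fold lower number from compound 3 to compound 4 (0.27 log units; within the scatter). This is the first change shown that removes both the sulfur and the aromatic ring from this saturated chain carbon, and a group of 7 heavy atoms gives way to one of 2 without a step beyond the scatter, so neither the sulfur nor that ring is needed here to match compound 3 on this read-out. The data shown offer no measured basis for assigning a cause to this result.

Since the sulfur and the ring leave together, the step cannot separate what each contributes, and a methylsulfanyl or a phenoxy group at this place would be needed to tell them apart. Going by these compounds, how a hydroxy group, an amine or a longer chain such as ethoxy would fare here also remains open.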